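The source may report more compounds than this note shows. Statements on the series, on what has been measured and on what is new or still open speak of the compounds shown alone.

Measured in an ADME assay on Akata cells (Homo sapiens) for cytotoxicity, with a stated time of 7 days; on this read-out lower numbers stand for higher toxicity in this test and higher numbers for lower toxicity in this test:

Compound 1 `Nc1nc(NCc2ccccc2)c2ncn(/C=C3/CC3(CO)CO)c2n1` gives > 24000 nM, a limit of the assay.
Compound 2 `CCCSc1nc(N)nc2c1ncn2/C=C1/CC1(CO)CO` gives > 20000 nM, again a limit.
Compound 3 `C=CCOc1nc(N)nc2c1ncn2/C=C1/CC1(CO)CO` gives > 20000 nM, also a limit.

Compound 2 therefore stands on no number at all in this assay; like the other two it sits at a limit, the one described by the limit of > 20000 nM in this assay, at which 2 of the 3 values shown sit, while compound 1 sits at the limit of > 24000 nM in this assay, at which 1 of the 3 values shown sits. The three steps among the measured compounds are a step that the two limits leave unreadable from compound 1 to compound 2, a step that the two limits leave unreadable from compound 1 to compound 3 and a step that the two limits leave unreadable from compound 2 to compound 3. None of them is readable in size. Every value involved is a limit.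

Compound 4 `CNc1nc(N)nc2c1ncn2/C=C1/CC1(CO)CO` is the next member. The change from compound 2 is methylamino in place of propylsulfanyl on an aromatic carbon. Going by the values given here, the steps that bear on it are the three unreadable ones above, so they give no size at all; what they do show is that exchanging the group on this aromatic carbon among benzylamino, propylsulfanyl and allyloxy left every compound at a limit in this assay. The expectation is therefore a step of no readable size, a step that the limit leaves unreadable from compound 2 to compound 4, with compound 4 most likely to be reported as a limit as well. Compound 4 is estimated at 30000 nM, within 15000 nM to 80000 nM.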

Compound 4, half-maximal cytotoxic concentration: > 24000 nM
Compound 4 gave a limit, no number; the forecaster's own chance of this, stated with the estimate: 85%; the middle value is on the limit's open side.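

No new step can be read: the steps from compound 1, compound 2 and compound 3 to compound 4 in this assay all join limits and have no readable size. The compounds shown leave open whether exchanging the group on this aromatic carbon changes cytotoxicity at all, since none of the four has a measured number.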